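Swapping a Chlorophenyl for a Cyanophenyl on a Ring Amine

A few compounds are considered here, and "the series" means these few. Any claim that something is new, unique, unknown or untested is made for them only; others in the source may bear on it.

Of the compounds shown here, three of this set have been tested in an ADME assay on L6 cells (Rattus norvegicus) for cytotoxicity; a higher number here means a weaker inhibitor, a lower number a stronger inhibitor. Compound 1 `O=C(Cn1ccnc1[N+](=O)[O-])N1CCN(c2ncccn2)CC1` gives 280000 nM. Compound 3 `Cc1ccc(N2CCN(CC(=O)N3CCN(c4ccc(C)cc4)CC3)CC2)cc1` gives 213000 nM. Compound 2 `O=C(Cn1cnc([N+](=O)[O-])n1)N1CCN(c2ccc(Cl)cc2)CC1` gives only a limit of the assay, > 285000 nM. That is where compound 2 stands: at the limit of > 285000 nM in this assay, at which 1 of the 3 values shown sits, with no number of its own. No two of the measured compounds differ in a single place, so no single step can be read from them; the two numbers that are known both point to weak inhibition, and the limit for compound 2 does not contradict that.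

Compound 4 `N#Cc1ccccc1N1CCN(C(=O)Cn2cnc([N+](=O)[O-])n2)CC1` has not been measured. It differs from compound 2 in one place: 2-cyanophenyl in place of 4-chlorophenyl on an amine nitrogen in a ring. Since every measured compound shows only weak inhibition, the step expected in this assay is an at least 1.0-fold lower number from compound 2 to compound 4 (0.00 log units; that floor lies within the scatter), none beyond the usual scatter. Compound 4 is expected to give about 280000 nM, most likely between 150000 nM and 600000 nM, with a fair chance that only a limit is reported again.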

Compound 4, half-maximal inhibitory concentration: 213000 nM
For compound 4 the middle estimate is 1.3-fold (0.12 log units) above the measured one; low and high end bracket the measured number.
By their numbers in this assay, from the lowest: compounds 3, 4 and 1 (each within the scatter of the next). At a limit, above all of these: compound 2.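

Among these compounds, this is the first change in the set that can be read at a single place: in this assay, 2-cyanophenyl in place of 4-chlorophenyl on an amine nitrogen in a ring gives an at least 1.3-fold lower number from compound 2 to compound 4 (0.12 log units; that floor lies within the scatter). Compound 4 has a number of its own where compound 2 has none, and that number still belongs to a weak inhibitor. The step can be given only as a floor because compound 2 stands at a limit of the assay: the limit of > 285000 nM in this assay, at which 1 of the 4 values shown sits.

On these data alone, how far compound 2 really lies from compound 4 remains open, so the true size of this step is unknown. Also open, as far as these compounds go, is what the same core would give with a plain phenyl, or with a methoxy group or a carboxylic acid on that ring.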